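Three compounds at the assay limit, and a fourth

The compounds below may be only part of what the source reports. "The series", "measured", "known", "first", "only" and "open" are said of these compounds alone.

Compound 1 `Cc1cc(Cl)cc(Cl)c1S(=O)(=O)N1CCC(N2CCC(C)CC2)CC1`: > 5000 nM
Compound 2 `COc1ccccc1-c1ccc(S(=O)(=O)N2CCC(N3CCC(C)CC3)CC2)cc1`: > 5000 nM
Compound 3 `COc1ccc(-c2cccc(S(=O)(=O)N3CCC(N4CCC(C)CC4)CC3)c2)cc1`: > 5000 nM

All three were tested in an ADME assay on HCT-116 cells (Homo sapiens) for cytotoxicity, read by CellTiter-Glo, with a stated time of 72 h; on this read-out lower numbers stand for stronger inhibition and higher numbers for weaker inhibition. Each value carries a greater-than sign, which means the assay reached its limit and gave no number. Compound 1 sits at that limit. Compound 2 also sits at that limit. Compound 3 sits at it too. So compound 2 stands where every other measured compound stands, at the limit of > 5000 nM in this assay, at which 3 of the 3 values shown sit; nothing here separates one compound from another.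

Compound 4 `CCCCOc1ccc(S(=O)(=O)N2CCC(N3CCC(C)CC3)CC2)cc1` has not yet been measured. It differs from compound 2 in one place: butoxy in place of 2-methoxyphenyl on an aromatic carbon. Within the data shown here, with no step between measured compounds to learn from, and with every measured compound at the limit, no change beyond the usual scatter of this assay is expected. Compound 4 is therefore expected to stay at the limit as well, with an estimated value of 8000 nM, between 4000 nM and 20000 nM, which means an expected step that the limit leaves unreadable from compound 2 to compound 4.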

Compound 4, half-maximal inhibitory concentration: > 5000 nM
Compound 4: only a limit was reported; the forecaster's own chance of this, stated with the estimate: 85%; the middle value lies beyond the limit too.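

Among these compounds, compound 2 and compound 4 both carry only a limit in this assay, so no step between them can be read: the limit of > 5000 nM in this assay, at which 4 of the 4 values shown sit. From the compounds shown here alone, whether any compound of this kind would give a real number in this assay stays open, as does what butoxy or 2-methoxyphenyl contributes.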